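Propyl for dimethylamino on the sulfonyl: clearance notes

The source may hold more compounds than are shown below. What is called first, only, known or untested is meant among the compounds shown, and "the series" means these compounds.

Measured in an in vitro ADME assay on microsomes from liver (Rattus norvegicus) for metabolic stability, read by LC-MS, tested at 1 uM; a lower number here means slower removal, a higher number faster removal of the compound:
- compound 1 `CCCS(=O)(=O)c1cccc(C#Cc2cc(Cl)ccc2OCC(=O)O)c1` (< 10 mL.min-1.g-1, a limit)
- compound 2 `CN(C)S(=O)(=O)c1ccc(F)c(C#Cc2cc(Cl)ccc2OCC(=O)O)c1` (< 10 mL.min-1.g-1, a limit)

For the measured compounds named here, the series so far shows only the limit of < 10 mL.min-1.g-1 in this assay, at which 2 of the 2 values shown sit, and gives no number to work from. Compound 2 stands at a limit of this assay (< 10 mL.min-1.g-1). The next compound, compound 3 `CCCS(=O)(=O)c1ccc(F)c(C#Cc2cc(Cl)ccc2OCC(=O)O)c1`, carries propyl in place of dimethylamino on a sulfonyl sulfur; cut one bond further out, this reads dimethylsulfamoyl to propylsulfonyl. Compound 1 also carries propylsulfonyl and also reads as a limit (< 10 mL.min-1.g-1). The expected step (a step that the limit leaves unreadable from compound 2 to compound 3) is estimated to stay within the usual scatter, with no direction expected. The estimate for compound 3 is 7 mL.min-1.g-1 (expected range 3 mL.min-1.g-1 to 15 mL.min-1.g-1).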

Compound 3, intrinsic clearance in microsomes: < 10 mL.min-1.g-1
Compound 3 gave a limit, no number; the forecaster's own chance of this, stated with the estimate: 70%; the middle value does not contradict the limit.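

Compound 3 also reads as a limit, so its steps from compound 2 and from compound 1 cannot be read in this assay: the limit of < 10 mL.min-1.g-1 in this assay, at which 3 of the 3 values shown sit.

The compounds shown leave open whether either propyl in place of dimethylamino or fluoro in place of hydrogen changes clearance at all.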